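A Halogen Swap on the Benzylamine Side Chain

The compounds below may be only part of what the source reports. "The series", "measured", "known", "first", "only" and "open" are said of these compounds alone.

compound 1 `O=c1cc(CNCc2ccccc2Br)oc2ccc(O)c(O)c12`: > 100000 nM
compound 2 `O=c1cc(CNCc2ccccc2I)oc2ccc(O)c(O)c12`: 87300 nM
compound 3 `O=c1cc(CNCc2ccccc2[N+](=O)[O-])oc2ccc(O)c(O)c12`: 41300 nM

The three measured compounds share one core and differ only in the group on the benzyl ring. In an ADME assay on Huh-7 cells (Homo sapiens) for cytotoxicity (on this read-out lower numbers stand for higher toxicity in this test and higher numbers for lower toxicity in this test), compound 2 gives 87300 nM, the higher of the two numbers reported. For compound 1, this assay reports only a limit, > 100000 nM. Compound 3 gives 41300 nM, and the step of a 2.1-fold lower number from compound 2 to compound 3 (0.33 log units; beyond the scatter) is the nearest to compound 2. The remaining measured steps are an at least 1.1-fold lower number from compound 1 to compound 2 (0.05 log units; that floor lies within the scatter) and an at least 2.4-fold lower number from compound 1 to compound 3 (0.38 log units; beyond the scatter).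

Compound 4 `O=c1cc(CNCc2cccc(Cl)c2)oc2ccc(O)c(O)c12` has not been measured; it differs from compound 2 by 3-chlorophenyl in place of 2-iodophenyl on a saturated chain carbon bound to an amine nitrogen. The step of an at least 1.1-fold lower number from compound 1 to compound 2 (0.05 log units; that floor lies within the scatter) bears on it most closely, being itself an exchange of one halogen for another, and it stayed within the scatter; only the nitro group moved the number beyond it. Compound 4 is therefore expected to sit near compound 2, with the step of a 1.0-fold higher number from compound 2 to compound 4 (0.01 log units; within the scatter) expected to stay within the scatter. The estimate for compound 4 is 90000 nM, between 40000 nM and 200000 nM, and the limit of > 100000 nM in this assay, at which 1 of the 3 values shown sits, shows that a limit rather than a number is also possible.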

Compound 4, half-maximal cytotoxic concentration: > 100000 nM
Compound 4: no number, only a limit; the forecaster's own chance of this, stated with the estimate: 40%; middle value at least 1.1-fold (0.04 log units) away from the limit.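

In this assay compound 4 gives > 100000 nM, which is a limit and not a number. Putting 3-chlorophenyl in place of 2-iodophenyl, on a saturated chain carbon bound to an amine nitrogen, gives an at least 1.1-fold higher number from compound 2 to compound 4 (0.05 log units; that floor lies within the scatter), so this change, which alters both the halogen and the name's ring number, brings no lowering of the number, although the floor of the step does not separate the two compounds. The step between compound 1 and compound 4 cannot be read, and the limit now recurs among the compounds: the limit of > 100000 nM in this assay, at which 2 of the 4 values shown sit.

The compounds shown leave open whether 2-chlorophenyl would read like 3-chlorophenyl, since the halogen and the ring number change together in this step. They also leave open how a carboxylic acid or an amine on the benzyl ring would read in this assay.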